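The source may hold more compounds than are shown below. What is called first, only, known or untested is meant among the compounds shown, and "the series" means these compounds.

Measured in a functional assay on the whole organism with Rattus norvegicus as the target; on this read-out higher numbers stand for an effect only at larger amounts of compound and lower numbers for an effect already at smaller amounts:
- compound 1 `CCOC(=O)C(=O)Nc1nc(-c2cc(C)no2)cs1` gives 0.7 mg/kg
- compound 2 `O=C(O)C(=O)Nc1nc(-c2cc(Cl)no2)cs1` gives > 30 mg/kg (a limit)

Compound 1 gives a true number in this assay, so the read-out can register activity in this series. Compound 2 has no number, and its > 30 mg/kg is only a limit of this assay.

Compound 3 `Cc1cc(-c2csc(NC(=O)C(=O)O)n2)on1` has methyl in place of chloro on an aromatic carbon. Among the compounds with values here, no measured step between compounds that differ in one place is available to size this change. The expectation therefore starts from compound 2 with its > 30 mg/kg, and no step beyond the scatter is expected in this assay in either direction. A second limit is quite possible. The expected change is a number no higher from compound 2 to compound 3 (the limit leaves the size open). For compound 3 the estimate is 30 mg/kg, with an expected range of 5 mg/kg to 100 mg/kg.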

Compound 3, dose for half-maximal effect: 6 mg/kg
For compound 3 the middle estimate is 5.0-fold (0.70 log units) above the measured one; low and high end bracket the measured number.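

In this assay, the aromatic carbon next to the ring nitrogen now proves able to move the read-out: methyl in place of chloro gives an at least 5.0-fold lower number from compound 2 to compound 3 (0.69 log units; beyond the scatter). Compound 2 stands at a limit, so this step has a minimum size only: the limit of > 30 mg/kg in this assay, at which 1 of the 3 values shown sits.

With methyl held, hydrogen in place of ethyl on an oxygen next to a carbonyl group gives an 8.6-fold higher number from compound 1 to compound 3 (0.93 log units; beyond the scatter), so the ethyl group is not required for a true number in this assay, though compound 1 keeps the lower one.

As far as these compounds go, how a hydrogen, a methoxy group or a longer chain such as propyl would read at this position remains open. So does whether methyl and chloro would keep the same order with ethyl on that oxygen.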